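The source may hold more compounds than are shown below. What is called first, only, known or untested is meant among the compounds shown, and "the series" means these compounds.

Measured compounds in an ADME assay on HepG2 cells (Homo sapiens) for cytotoxicity, read by MTT assay, with a stated time of 24 h; on this read-out higher numbers stand for lower toxicity in this test and lower numbers for higher toxicity in this test:

Compound 1 `CC(C)=CCC1=C(OCc2cn(-c3ccnc4cc(Cl)ccc34)nn2)C(=O)c2ccccc2C1=O` gives 1940000 nM.
Compound 2 `CC(C)=CCC1=C(OCc2cn(-c3ccccc3)nn2)C(=O)c2ccccc2C1=O` gives 100000 nM.
Compound 3 `CC(C)=CCC1=C(OCc2cn(-c3ccc(C#N)cc3)nn2)C(=O)c2ccccc2C1=O` gives 707000 nM.

Within these three, compound 3 stands second highest in this assay, below compound 1 by a 2.7-fold lower number from compound 1 to compound 3 (0.44 log units; beyond the scatter) and above compound 2, the step of a 7.1-fold higher number from compound 2 to compound 3 (0.85 log units; beyond the scatter). Both gaps lie beyond the scatter.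

Compound 4 `COc1ccc(-n2cc(COC3=C(CC=C(C)C)C(=O)c4ccccc4C3=O)nn2)cc1` is not yet measured. It differs from compound 3 by methoxy in place of cyano on an aromatic carbon, on an aromatic carbon of a six-membered aromatic ring of carbon only.

For the measured compounds named here, no measured step swaps these two groups directly. The step that bears on it is the one from the unsubstituted ring to the cyano-bearing ring, a 7.1-fold higher number from compound 2 to compound 3 (0.85 log units; beyond the scatter), which is modest. Removing the cyano in favour of methoxy, another group with one heavy-atom acceptor and no donor, is expected to undo part of that step rather than move beyond compound 2. The pair of compounds 1 and 2 shows that the aryl group on the triazole nitrogen can shift the number strongly, a 19-fold lower number from compound 1 to compound 2 (1.29 log units; beyond the scatter), so a shift is plausible.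

For compound 4 a modest step lower than compound 3 is expected, a 2.4-fold lower number from compound 3 to compound 4 (0.37 log units; beyond the scatter). Compound 4 is estimated at 300000 nM, within 100000 nM to 900000 nM.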

Compound 4, half-maximal cytotoxic concentration: 200000 nM
The estimate for compound 4 lay 1.5-fold (0.18 log units) above the measured number; low and high end bracket the measured number.
By their numbers in this assay, from the lowest: compounds 2 and 4 (each within the scatter of the next); then compound 3; then compound 1.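

In this assay the change from cyano to methoxy on the aromatic carbon para to a large group gives a 3.5-fold lower number from compound 3 to compound 4 (0.55 log units; beyond the scatter) and, set against the unsubstituted ring, a 2.0-fold higher number from compound 2 to compound 4 (0.30 log units; within the scatter) which lies within the scatter, so in this test methoxy cannot be told apart from hydrogen at this place, while cyano can. The two groups that swap here have the same counts of heavy atoms, hydrogen-bond donors and hydrogen-bond acceptors, so those counts alone do not set the number at this place, and the 4-methoxyphenyl group also stays well apart from the 7-chloroquinolin-4-yl group, with a 9.7-fold lower number from compound 1 to compound 4 (0.99 log units; beyond the scatter) as the step between them. Nothing measured here accounts for the difference between cyano and methoxy.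

The compounds shown leave open whether cyano is an isolated case at this place or whether other groups, such as a chlorine atom, an amine or a carboxylic acid, would also separate from hydrogen. They also leave open whether cyano or methoxy would give the same result on another carbon of the same ring, or on the shared core with a different chain in place of the present one.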